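The source may hold more compounds than are shown below. What is called first, only, known or untested is meant among the compounds shown, and "the series" means these compounds.

Working notes on the series. In an ADME assay on microsomes from liver (Homo sapiens) for pharmacokinetics (on this read-out lower numbers stand for slow clearance and higher numbers for fast clearance), compound 2 `Cn1cc(-c2ncc(C#N)c(N3C[C@@H]4C[C@H]3CN4c3cccc(F)c3)n2)cn1` gives 76 mL/min/kg, the highest of the two numbers in hand. Compound 1 `C[C@@H]1CN(c2nc(-c3cnn(C)c3)ncc2C#N)CCN1C(=O)C1CC1` gives 21 mL/min/kg in this assay, a lower number beyond the scatter. Compound 3 `C[C@@H]1C[C@H]1C(=O)N1CCN(c2nc(-c3cnn(C)c3)ncc2C#N)C[C@H]1C` is reported in this assay only as a limit, < 16 mL/min/kg, namely (the limit of < 16 mL/min/kg in this assay, at which 1 of the 3 values shown sits).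

Compound 4 `Cn1cc(-c2ncc(C#N)c(N3C[C@@H]4C[C@H]3CN4S(=O)(=O)C3CC3)n2)cn1` differs from compound 2 by cyclopropylsulfonyl in place of 3-fluorophenyl on an amine nitrogen in a ring. For the measured compounds named here, no measured step covers this exchange; the single step in hand, an at least 1.3-fold lower number from compound 1 to compound 3 (0.11 log units; that floor lies within the scatter), concerns a saturated ring carbon and lies within the scatter. Compounds 1 and 3, which both lack the 3-fluorophenyl, return lower numbers than compound 2, so a drop is expected for compound 4, estimated as the step of a 3.5-fold lower number from compound 2 to compound 4 (0.54 log units; beyond the scatter). Compound 4 is expected at 22 mL/min/kg, between 10 mL/min/kg and 45 mL/min/kg.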

Compound 4, clearance: < 16 mL/min/kg
Compound 4 was reported as a limit; the forecaster's own chance of this, stated with the estimate: 25%; at least 1.3-fold (0.13 log units) between middle value and limit.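

Cyclopropylsulfonyl in place of 3-fluorophenyl on an amine nitrogen in a ring gives an at least 4.7-fold lower number from compound 2 to compound 4 (0.67 log units; beyond the scatter) in this assay. For the compounds shown here, this position therefore moves the read-out on an unchanged core, which the earlier compounds, with no exchange at this nitrogen, could not show. Compound 4 is a limit, not a number, so the full size of the drop stays unread: the limit of < 16 mL/min/kg in this assay, at which 2 of the 4 values shown sit.

On these data alone, whether the drop goes with the sulfonyl or with the loss of the aromatic ring remains open. Where an acetyl or a benzyl group on this nitrogen would fall is also open.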